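From an aryl amide to a 1-carboxyethyl amide

This account rests on a few compounds, and the source may have more. Where it says the series, first, only, none or still open, it means among the compounds named here.

Measured in a functional assay on HepG2 cells (Homo sapiens) for antiproliferative activity, read by MTT assay, with a stated time of 48 h; on this read-out higher numbers stand for weaker inhibition and lower numbers for stronger inhibition:
- Compound 1 `CCn1c(C(=O)NCCN(C)C)ccc1C(CC)(CC)c1ccc(OCCC(O)(CC)CC)c(C)c1`: 240 nM
- Compound 2 `CCn1c(C(=O)Nc2cccc(C(F)(F)F)c2)ccc1C(CC)(CC)c1ccc(OCCC(O)(CC)CC)c(C)c1`: > 50000 nM, a limit
- Compound 3 `CCOc1ccc(NC(=O)c2ccc(C(CC)(CC)c3ccc(OCCC(O)(CC)CC)c(C)c3)n2CC)cc1`: > 50000 nM, a limit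

Compound 2 has no exact number, because its > 50000 nM is a limit of the assay. Compound 3 also gives only a limit, > 50000 nM. Both sit at the limit of > 50000 nM in this assay, at which 2 of the 3 values shown sit.

Compound 4 `CCn1c(C(=O)NC(C)C(=O)O)ccc1C(CC)(CC)c1ccc(OCCC(O)(CC)CC)c(C)c1` has not yet been measured. Its difference from compound 2 is 1-carboxyethyl in place of 3-(trifluoromethyl)phenyl on an amide-type nitrogen.

Among the measured compounds shown here, two measured steps bear on this change, both large and beyond the scatter: an at least 200-fold higher number from compound 1 to compound 2 (2.31 log units; beyond the scatter) and an at least 200-fold higher number from compound 1 to compound 3 (2.31 log units; beyond the scatter). Each puts an aromatic ring on that nitrogen in place of 2-(dimethylamino)ethyl. Compound 4 lacks such a ring, but its chain differs from that of compound 1, so in this assay only a partial move toward the 240 nM of compound 1 is expected. The expected change is an at least 6.2-fold lower number from compound 2 to compound 4 (0.79 log units; beyond the scatter). For compound 4, the estimated value is 8000 nM, with an expected range of 600 nM to 50000 nM.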

Compound 4, half-maximal inhibitory concentration: 1740 nM
Beside the measured number, compound 4's estimate is 4.6-fold (0.66 log units) above it; the measured number falls inside the stated range.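

Until now, only the 2-(dimethylamino)ethyl chain of compound 1 gave an exact number on this amide-type nitrogen, but in this assay the 1-carboxyethyl group also gives one, with an at least 28-fold lower number from compound 2 to compound 4 (1.45 log units; beyond the scatter) and an at least 28-fold lower number from compound 3 to compound 4 (1.45 log units; beyond the scatter). These two steps are only minimum sizes, since compound 2 and compound 3 each give a limit and not a number: the limit of > 50000 nM in this assay, at which 2 of the 4 values shown sit. An exact number on this nitrogen therefore does not depend on a dimethylamino group, although swapping that chain for 1-carboxyethyl still gives a 7.3-fold higher number from compound 1 to compound 4 (0.86 log units; beyond the scatter).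

The compounds shown do not separate the role of the carboxylic acid from the simple absence of an aromatic ring on this nitrogen. A plain ethyl or 2-hydroxyethyl group there, or a longer chain ending in an amine, would help to tell these apart.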